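From an Isopropoxycarbonyl to an Acetyl Group

The compounds below may be only part of what the source reports. "The series", "measured", "known", "first", "only" and "open" are said of these compounds alone.

Within the data shown here, in a physicochemical assay for permeability, using PAMPA, at pH 7.4 (on this read-out higher numbers stand for higher permeability and lower numbers for lower permeability), compound 3 `CC(C)OC(=O)NCCS(=O)(=O)NC(=O)c1ccc(Nc2nc(NC3(c4ccc(Cl)cc4)CC3)nc(OCC(F)(F)F)n2)cc1` gives 71 nm/s, the lowest of the three numbers measured so far. Compound 1 `O=C(NS(=O)(=O)c1ccc(F)cc1)c1ccc(Nc2nc(NC3(c4ccc(Cl)cc4)CC3)nc(OCC(F)(F)F)n2)cc1` gives 193 nm/s, and compound 2 `CC(C)(C)OC(=O)NCCS(=O)(=O)NC(=O)c1ccc(Nc2nc(NC3(c4ccc(Cl)cc4)CC3)nc(OCC(F)(F)F)n2)cc1` gives 111 nm/s. The step of a 2.7-fold lower number from compound 1 to compound 3 (0.43 log units; beyond the scatter) lies beyond the scatter, whereas a 1.7-fold lower number from compound 1 to compound 2 (0.24 log units; within the scatter) and a 1.6-fold lower number from compound 2 to compound 3 (0.19 log units; within the scatter) do not. Compound 4 `CC(=O)NCCS(=O)(=O)NC(=O)c1ccc(Nc2nc(NC3(c4ccc(Cl)cc4)CC3)nc(OCC(F)(F)F)n2)cc1` differs from compound 3 by methyl in place of isopropoxy on a carbonyl carbon. The measured step that bears most on this change is a 1.6-fold lower number from compound 2 to compound 3 (0.19 log units; within the scatter), where a related trimming of the same side chain went with a drop that stayed within the scatter. A similar or somewhat larger step downward is therefore expected, a 1.4-fold lower number from compound 3 to compound 4 (0.15 log units; within the scatter), although a change hidden in the scatter remains possible. Compound 4 is expected to give 50 nm/s, within a range of 25 nm/s to 100 nm/s.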

Compound 4, apparent permeability: 7 nm/s
Compound 4: middle estimate off by 7.1-fold (0.85 log units), on the high side, outside the stated range (below it).
By their numbers in this assay, from the lowest: compound 4; then compounds 3, 2 and 1 (each within the scatter of the next, the first and the last beyond it).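

In this assay, among these compounds, the group on this carbonyl carbon matters far more than the earlier compounds showed: a 10-fold lower number from compound 3 to compound 4 (1.01 log units; beyond the scatter) with methyl in place of isopropoxy, and a 16-fold lower number from compound 2 to compound 4 (1.20 log units; beyond the scatter) with methyl in place of tert-butoxy, both far exceed the step within the scatter between the two alkoxy groups. Replacing 4-fluorophenyl on the sulfonyl sulfur with 2-acetamidoethyl gives a 28-fold lower number from compound 1 to compound 4 (1.44 log units; beyond the scatter) for the whole change. Nothing available explains these drops. As far as these compounds go, whether a methylamino, ethyl or methoxy group on this carbonyl carbon would track methyl or the larger alkoxy groups remains open.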